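The source may hold more compounds than are shown below. What is called first, only, known or untested is meant among the compounds shown, and "the series" means these compounds.

Measured compounds: compound 1 `Cc1ccccc1CCC(=O)N[C@@H](C(=O)N1CCC(c2ccc(Cl)cc2)CC1)C(C)C` with 19 nM; compound 2 `CC(C)[C@@H](NC(=O)CC1CC1)C(=O)N1CCC(c2ccc(Cl)cc2)CC1` with 46 nM.

Among the measured compounds shown here, in an assay on THP-1 cells for displacement of a labelled ligand from C-C chemokine receptor type 1 (Homo sapiens) (on this read-out lower numbers stand for stronger inhibition and higher numbers for weaker inhibition), compound 2 gives 46 nM, the higher of the two numbers; its only neighbour is compound 1 at 19 nM. Compound 3 `CC(C)[C@@H](NC(=O)c1ccc(F)c(F)c1)C(=O)N1CCC(c2ccc(Cl)cc2)CC1` differs from compound 2 by 3,4-difluorophenyl in place of cyclopropylmethyl on a carbonyl carbon. For the measured compounds named here, the single measured step that bears on this position is a 2.4-fold higher number from compound 1 to compound 2 (0.38 log units; beyond the scatter), where cyclopropyl in place of 2-methylbenzyl raised the number modestly. Returning an aromatic ring to this position, now on the carbonyl carbon itself, is expected to give a step of similar size in the lower direction, a 2.1-fold lower number from compound 2 to compound 3 (0.32 log units; beyond the scatter). Compound 3 is therefore expected to give 22 nM, with a range of 8 nM to 70 nM.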

Compound 3, half-maximal inhibitory concentration: 14 nM
For compound 3 the middle estimate is 1.6-fold (0.20 log units) above the measured one; measured number inside the range.
By their numbers in this assay, from the lowest: compounds 3 and 1 (each within the scatter of the next); then compound 2.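

Directly on the carbonyl carbon, an aromatic ring is tolerated: 3,4-difluorophenyl in place of cyclopropylmethyl gives a 3.3-fold lower number from compound 2 to compound 3 (0.52 log units; beyond the scatter) in this assay and so improves on the small saturated group. The longer 2-(2-methylphenyl)ethyl chain is not required for a low number, as its replacement by 3,4-difluorophenyl gives a 1.4-fold lower number from compound 1 to compound 3 (0.13 log units; within the scatter) and leaves the two compounds level. No supporting data explain these differences.

Still open, on these data alone, is whether the two fluorines contribute at all, which unsubstituted phenyl would test. A pyridine ring on the same carbonyl carbon also remains to be placed against these numbers.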